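Swapping a trifluoromethyl for a nitro on the benzoate ring

A few compounds are considered here, and "the series" means these few. Any claim that something is new, unique, unknown or untested is made for them only; others in the source may bear on it.

Three esters of the same core have been tested in a functional assay on K562 cells (Homo sapiens) for antiproliferative activity, read by sulforhodamine B assay, with a stated time of 48 h, tested at 50 uM; on this read-out lower numbers stand for less inhibition and higher numbers for more inhibition at the one concentration tested (going by the name of the read-out). Compound 1 `COc1cccc(C(=O)Oc2cc3c(cc2C)[C@@H](C(C)C)CC=C3C)c1` carries a methoxy on the benzoate ring, and in this assay compound 1 gives "not active" (no number reported). Compound 2 `CC1=CC[C@H](C(C)C)c2cc(C)c(OC(=O)c3ccccc3)cc21` has an unsubstituted benzoate, and in this assay compound 2 gives "not active" (no number reported). Compound 3 `CC1=CC[C@H](C(C)C)c2cc(C)c(OC(=O)c3cccc(C(F)(F)F)c3)cc21` carries a trifluoromethyl, and in this assay compound 3 gives 45.5%, the only figure reported in the series; the other two entries carry no number at all.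

Compound 4 `CC1=CC[C@H](C(C)C)c2cc(C)c(OC(=O)c3cccc([N+](=O)[O-])c3)cc21` differs from compound 3 in one place: nitro in place of trifluoromethyl on an aromatic carbon. Both groups sit on the same aromatic carbon, meta to the large ester group. Among the compounds with values here, no pair of measured compounds differs in exactly one place, so there is no measured step to lean on. Compound 3 shows that a substituent of this kind at this position can give a moderate read-out, while compound 1 and compound 2 show that other benzoates fall out of the numbered range. The nitro is expected to behave somewhere between those outcomes, with the step of a number 10.5 percentage points lower from compound 3 to compound 4 (beyond the scatter) expected to lie within or just beyond the scatter, in the downward direction. For compound 4 the expected value is therefore 35%, with a range from 10% to 60%.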

Compound 4, a percentage reported as inhibition, at one concentration (the size of the read-out at that concentration, not a potency): 15.9%
Compound 4: middle estimate off by 19.1 percentage points, on the high side; low and high end bracket the measured number.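

In this assay, nitro in place of trifluoromethyl gives a number 29.6 percentage points lower from compound 3 to compound 4 (beyond the scatter) on the same aromatic carbon, with the rest of the molecule unchanged. Within the data shown here, this is the first measured change in one place, and it shows that the read-out depends on which group sits at this position, meta to a large group; the nitro compound still gives a number, but a smaller one. No measurement shown here accounts for the step, so the reason for it stays unknown.

Two compounds with numbers cannot show how far the read-out can move at this position, and an amine, a carboxylic acid or a nitrile on the same carbon would test this further. As far as these compounds go, whether nitro or trifluoromethyl would give similar numbers on other carbons of the ring also remains open.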